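The source may hold more compounds than are shown below. What is called first, only, known or untested is meant among the compounds shown, and "the series" means these compounds.

Measured so far in a functional assay (trachea) with Cavia porcellus as the target; on this read-out higher numbers stand for weaker inhibition and lower numbers for stronger inhibition:
- compound 1, `CCCCCCCCn1nc(-c2cccnc2)c2ccccc2c1=O`: 21900 nM
- compound 2, `O=c1c2ccccc2c(-c2cccnc2)nn1CC1CCCCC1`: 209 nM
- compound 3, `O=c1c2ccccc2c(-c2cccnc2)nn1Cc1ccccc1`: 2450 nM

Among these three, compound 2 gives the lowest number, and both of its steps to the others lie beyond the scatter: the step of a 12-fold higher number from compound 2 to compound 3 (1.07 log units; beyond the scatter) is large, and the step of a 100-fold lower number from compound 1 to compound 2 (2.02 log units; beyond the scatter) is even larger, so compound 2 is the strongest inhibitor of the set in this assay.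

The next compound, compound 4, `O=C(O)c1ccc(Cn2nc(-c3cccnc3)c3ccccc3c2=O)cc1`, is not yet measured. It differs from compound 2 in one place: 4-carboxyphenyl in place of cyclohexyl on a saturated chain carbon bound to an aromatic nitrogen.

One measured step speaks to this change. Replacing cyclohexyl with plain phenyl at the same position gave a 12-fold higher number from compound 2 to compound 3 (1.07 log units; beyond the scatter), a weakening. Compound 4 carries that same phenyl ring, now bearing a carboxylic acid. Within the data shown here, no measured pair shows what such an acid does here, so the expectation rests on the phenyl step alone, widened for the unknown acid.

Compound 4 is therefore expected to give a number higher than compound 2, around the level of compound 3, with an estimated step of a 14-fold higher number from compound 2 to compound 4 (1.16 log units; beyond the scatter). The estimated value for compound 4 is 3000 nM, expected to fall between 500 nM and 20000 nM.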

Compound 4, half-maximal inhibitory concentration: 17000 nM
Compound 4: the middle estimate sits 5.7-fold (0.75 log units) below what was measured; the measured number falls inside the stated range.
By their numbers in this assay, from the lowest: compound 2; then compound 3; then compounds 4 and 1 (each within the scatter of the next).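

Among these compounds, putting a carboxy group in place of hydrogen on the phenyl ring gives, in this assay, a 6.9-fold higher number from compound 3 to compound 4 (0.84 log units; beyond the scatter), so a substituent on this ring can itself weaken inhibition, something the earlier compounds, whose phenyl ring was bare, could not show. The full change from cyclohexyl to 4-carboxyphenyl therefore adds up to an 81-fold higher number from compound 2 to compound 4 (1.91 log units; beyond the scatter), a larger step than the move to plain phenyl alone, with both parts of the change pointing towards weaker inhibition. The heptyl and 4-carboxyphenyl groups also end up level, with a 1.3-fold lower number from compound 1 to compound 4 (0.11 log units; within the scatter) lying within the scatter, so the carboxy group cancels the advantage that the plain phenyl ring held over the heptyl chain.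

Nothing shown here explains why the carboxy group has this effect on the number. From the compounds shown here alone, it also remains open whether this weakening is specific to the carboxylic acid, or whether a methyl ester, an amide or an amine on the same phenyl ring would give a similar step, and what a carboxylic acid on the cyclohexyl ring of compound 2 would do.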